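Cyclopentyl for 6-hydroxyhexyl on the sulfonyl side chain

This account rests on a few compounds, and the source may have more. Where it says the series, first, only, none or still open, it means among the compounds named here.

In a functional assay, read by fluorescence and spectrophotometry, with a stated time of 1 h (on this read-out higher numbers stand for an effect only at larger amounts of compound and lower numbers for an effect already at smaller amounts), compound 1 (`O=S(=O)(/C=C/c1ccc(O)c(O)c1)CC1CCC1`) gives 8800 nM, compound 2 (`CCCCCCS(=O)(=O)/C=C/c1ccc(O)c(O)c1`) gives 7300 nM and compound 3 (`O=S(=O)(/C=C/c1ccc(O)c(O)c1)CCCCCCCCO`) gives 6700 nM. Compound 3 thus stands level with the other two, as all three numbers lie within the scatter of each other.

Compound 4 (`O=S(=O)(/C=C/c1ccc(O)c(O)c1)CCC1CCCC1`) is the next to be read. It has cyclopentyl in place of 6-hydroxyhexyl on a saturated chain carbon, two bonds along the chain from a sulfonyl sulfur.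

Within the data shown here, two measured steps bear on this change. One is a 1.2-fold lower number from compound 1 to compound 2 (0.08 log units; within the scatter), with pentyl in place of cyclobutyl. The other is a 1.1-fold lower number from compound 2 to compound 3 (0.04 log units; within the scatter), with 2-hydroxyethyl in place of hydrogen. Both are small and within the scatter, so no step beyond the scatter is expected in this assay.

The expected change is a 1.1-fold higher number from compound 3 to compound 4 (0.05 log units; within the scatter).

Compound 4 is estimated at 7500 nM, with an expected range of 4500 nM to 12000 nM.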

Compound 4, half-maximal effective concentration: 6800 nM
Compound 4: the middle estimate sits 1.1-fold (0.04 log units) above what was measured, within the range that was stated.
By their numbers in this assay, from the lowest: compounds 3, 4, 2 and 1 (each within the scatter of the next).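

Working notes: in this assay, cyclopentyl in place of 6-hydroxyhexyl gives no step beyond the scatter (a 1.0-fold higher number from compound 3 to compound 4 (0.01 log units; within the scatter)), so at this position a five-membered non-aromatic ring of carbon only stands level with an open chain carrying a hydroxyl group. The same holds for cyclopentyl in place of butyl (a 1.1-fold lower number from compound 2 to compound 4 (0.03 log units; within the scatter)) and for cyclopentylmethyl in place of cyclobutyl (a 1.3-fold lower number from compound 1 to compound 4 (0.11 log units; within the scatter)), which extends the level picture to all three earlier side chains. No supporting data bear on why these side-chain changes leave the number level.

On these data alone, whether an amine or a carboxylic acid on this side chain, or a much shorter chain such as methyl, would give a step beyond the scatter remains open. Also open, as far as these compounds go, is how far the number depends on the shared core rather than on the side chain.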